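The compounds below may be only part of what the source reports. "The series", "measured", "known", "first", "only" and "open" are said of these compounds alone.

Of the compounds shown here, three built on the same core have been tested in a functional assay on A549 cells (Homo sapiens) for inhibition, read by MTT assay, with a stated time of 72 h; on this read-out lower numbers stand for stronger inhibition and higher numbers for weaker inhibition. Compound 1 `CC(C)(C)n1cc2c(n1)C(=O)CC1(CCN(C(=O)c3cc(-c4ccc(Cl)cc4)nc4ccccc34)CC1)O2` gives 2330 nM. Compound 2 `CC(C)(C)n1cc2c(n1)C(=O)CC1(CCN(C(=O)c3cc(-c4ccc(Br)cc4)nc4ccccc34)CC1)O2`, which differs from compound 1 only by a 4.0-fold higher number from compound 1 to compound 2 (0.60 log units; beyond the scatter), gives 9300 nM and stands with the highest number of the three. Compound 3 `CC(C)(C)n1cc2c(n1)C(=O)CC1(CCN(C(=O)c3cc(-c4ccncc4)nc4ccccc34)CC1)O2` gives 550 nM; this follows from a 4.2-fold lower number from compound 1 to compound 3 (0.63 log units; beyond the scatter) and from a 17-fold lower number from compound 2 to compound 3 (1.23 log units; beyond the scatter).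

Compound 4 `Cc1cc(C(=O)N2CCC3(CC2)CC(=O)c2nn(C(C)(C)C)cc2O3)c2ccccc2n1` has not yet been measured. It differs from compound 2 by methyl in place of 4-bromophenyl on an aromatic carbon. Among the compounds with values here, of the measured steps, the one from compound 2 to compound 3 bears most closely on it, since both replace the 4-bromophenyl group, and that step was large. The step from compound 1 to compound 2 shows that even a small change to this group moves the number beyond the scatter. Within the data shown here, no measured compound carries a methyl here, so the direction is uncertain, but a lower number than compound 2 is expected, as the step of a 3.7-fold lower number from compound 2 to compound 4 (0.57 log units; beyond the scatter) expresses. Compound 4 is therefore estimated at 2500 nM, within a range from 500 nM to 12000 nM.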

Compound 4, half-maximal inhibitory concentration: > 10000 nM
Compound 4 gave a limit, no number; the forecaster's own chance of this, stated with the estimate: 10%; at least 4.0-fold (0.60 log units) between middle value and limit.
By their numbers in this assay, from the lowest: compound 3; then compound 1; then compound 2. At a limit, above all of these: compound 4.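

Compound 4 gave a limit of the assay and no number: the limit of > 10000 nM in this assay, at which 1 of the 4 values shown sits. Cutting the six-membered aromatic ring at this place down to a single methyl gives weaker inhibition than the 4-chlorophenyl group, with an at least 4.2-fold higher number from compound 1 to compound 4 (0.63 log units; beyond the scatter), and weaker inhibition than the pyridin-4-yl group, with an at least 18-fold higher number from compound 3 to compound 4 (1.25 log units; beyond the scatter). Against the 4-bromophenyl group the order stays unsettled, with an at least 1.0-fold higher number from compound 2 to compound 4 (0.03 log units; that floor lies within the scatter), so an aromatic ring at this place is linked to the lower numbers in compound 1 and compound 3, while compound 2 cannot be separated from the methyl.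

As far as these compounds go, how far above its limit compound 4 truly lies remains unknown. Also open, from the compounds shown here alone, is whether a longer chain such as butyl, a saturated ring such as piperidine, or an amine at this place would behave like the methyl or like the pyridin-4-yl group.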